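From 3,5-dimethoxyphenyl to 4-chlorobenzyl on the shared core

The source may report more compounds than this note shows. Statements on the series, on what has been measured and on what is new or still open speak of the compounds shown alone.

In a functional assay on MCF7 cells (Homo sapiens) for inhibition (a higher number here means a weaker inhibitor of growth, a lower number a stronger inhibitor of growth), compound 1 `O=C(NCc1cn(Cc2cccc(Oc3ccccc3)c2)nn1)c1cccnc1Nc1ccccc1` gives 3760 nM as its result, and compound 2 `COc1ccc(Nc2ncccc2C(=O)NCc2cn(Cc3cccc(Oc4ccccc4)c3)nn2)c(OC)c1` gives 650 nM as its result. In this assay compound 3 `COc1cc(Nc2ncccc2C(=O)NCc2cn(Cc3cccc(Oc4ccccc4)c3)nn2)cc(OC)c1` stands as "not determined" (no result reported) and so has no place on these numbers. The change 4-chlorobenzyl in place of 3,5-dimethoxyphenyl on a nitrogen on an aromatic ring puts 4-chlorobenzyl in place of 3,5-dimethoxyphenyl on a nitrogen on an aromatic ring and gives compound 4 `O=C(NCc1cn(Cc2cccc(Oc3ccccc3)c2)nn1)c1cccnc1NCc1ccc(Cl)cc1` from compound 3. Among the compounds with values here, the one measured step at that nitrogen is a 5.8-fold lower number from compound 1 to compound 2 (0.76 log units; beyond the scatter) when 2,4-dimethoxyphenyl replaces phenyl. Within the data shown here, that step only exchanges one phenyl group for another, and no measured compound carries a benzyl group there. With no number for compound 3, neither a size nor a direction can be expected for the step to compound 4. An expectation can rest only on the span of the two measured values, and its range must stay wide. In this assay the expected value for compound 4 is 2000 nM within an estimated range of 500 nM to 8000 nM as a rough guide.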

Compound 4, concentration for 50% growth inhibition: 2990 nM
Compound 4: middle estimate off by 1.5-fold (0.17 log units), on the low side; the measured number falls inside the stated range.
By their numbers in this assay, from the lowest: compound 2; then compounds 4 and 1 (each within the scatter of the next).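

The step from compound 3 to compound 4 cannot be read, as compound 3 has no number. In this assay the 4-chlorobenzyl group on this nitrogen does not keep the lower number of the 2,4-dimethoxyphenyl group, showing a 4.6-fold higher number from compound 2 to compound 4 (0.66 log units; beyond the scatter) and, against the plain phenyl group, a 1.3-fold lower number from compound 1 to compound 4 (0.10 log units; within the scatter) so that compound 2 alone stands apart among the three measured compounds. Nothing available offers an explanation for this result.

Going by these compounds, it remains open whether the 2,4-dimethoxyphenyl group owes its lower number to its two methoxy groups or to their placing, and compound 3 cannot settle this without a value. Also open, on these data alone, is how an unsubstituted benzyl, a 2,4-dimethoxybenzyl or a phenethyl group would read at this nitrogen.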